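This account rests on a few compounds, and the source may have more. Where it says the series, first, only, none or still open, it means among the compounds named here.

Compound 2 `COc1ccc(CS(=O)(=O)/C=C/c2ccc(OC)c(OC)c2)cc1` is one of three measured compounds that share a core and differ only in the methoxy pattern on one ring. In a functional assay on DLD-1 cells (Homo sapiens) for antiproliferative activity, read by trypan blue exclusion (a lower number here means a stronger inhibitor, a higher number a weaker inhibitor), compound 2 gives only a limit, > 20000 nM. Compound 1 `COc1ccc(/C=C/S(=O)(=O)Cc2ccc(OC)cc2)cc1` likewise gives a limit, > 20000 nM. Compound 3 `COc1ccc(CS(=O)(=O)/C=C/c2ccc(OC)c(OC)c2OC)cc1` also gives a limit, > 20000 nM. The steps a step that the two limits leave unreadable from compound 1 to compound 2 and a step that the two limits leave unreadable from compound 2 to compound 3 are therefore of unreadable size, since (the limit of > 20000 nM in this assay, at which 3 of the 3 values shown sit). Compound 4 `COc1ccc(CS(=O)(=O)/C=C/c2cc(OC)c(OC)c(OC)c2)cc1` carries one further change relative to compound 2: methoxy in place of hydrogen on an aromatic carbon. With every measured value sitting at the limit, no step can be read, and compound 4 is expected to remain there as well, so the step that the limit leaves unreadable from compound 2 to compound 4 is estimated as no gain beyond the scatter. Compound 4 is thus estimated at 25000 nM, within 3000 nM to 100000 nM.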

Compound 4, half-maximal inhibitory concentration: > 20000 nM
Compound 4 was reported as a limit; the forecaster's own chance of this, stated with the estimate: 70%; the middle value does not contradict the limit.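

Compound 4, like compound 2, is reported only as a limit, so no step between them can be read: the limit of > 20000 nM in this assay, at which 4 of the 4 values shown sit.

The compounds shown leave open how these methoxy patterns truly rank in this assay.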